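A few compounds are considered here, and "the series" means these few. Any claim that something is new, unique, unknown or untested is made for them only; others in the source may bear on it.

Compound 1, `CCOC(=O)c1sc(-c2nc3ccccc3n2CC)nc1C`: in a functional assay on MCF7 cells (Homo sapiens) for cytotoxicity, read by MTT assay, with a stated time of 24 h (a lower number here means a stronger inhibitor, a higher number a weaker inhibitor), compound 1 reaches only the assay limit, > 20000 nM.
Compound 2, `CCOC(=O)c1sc(-c2nc3ccccc3n2Cc2ccccc2)nc1C`: in this assay compound 2 likewise gives only a limit, > 20000 nM.
Compound 3, `CCOC(=O)c1csc(-c2nc3ccccc3n2C)n1`: in this assay compound 3 gives only a limit, > 20000 nM.

Compound 3 thus stands at the limit of the assay, and the two further values shown are limits as well; all three sit at the limit of > 20000 nM in this assay, at which 3 of the 3 values shown sit. The unmeasured compound 4, `CCOC(=O)c1csc(-c2nc3ccccc3n2CC)n1`, differs from compound 3 by methyl in place of hydrogen on a saturated chain carbon bound to an aromatic nitrogen. Among the measured compounds shown here, only one measured step touches the same place: a step that the two limits leave unreadable from compound 1 to compound 2, and since both of its ends are limits its size cannot be read. The measured compounds therefore give neither a direction nor a size for the change from compound 3 to compound 4, and because every value shown sits at the limit of > 20000 nM in this assay, at which 3 of the 3 values shown sit, the step in this assay is expected to leave compound 4 at the limit too. The estimate for compound 4 is 30000 nM, within 15000 nM to 100000 nM. The expected step that the limit leaves unreadable from compound 3 to compound 4 is accordingly one of no readable size.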

Compound 4, half-maximal inhibitory concentration: > 20000 nM
Compound 4 was reported as a limit (the forecaster's own chance of this, stated with the estimate: 85%); the middle value is on the limit's open side.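

Compound 3 and compound 4 both stand only as limits in this assay, so no new step can be read between them. The compounds shown leave open whether any change to them alters the read-out at all, because every value rests on one limit: the limit of > 20000 nM in this assay, at which 4 of the 4 values shown sit.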